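The source may report more compounds than this note shows. Statements on the series, on what has been measured and on what is new or still open speak of the compounds shown alone.

Compound 1 `CCOC(=O)[C@@]1(C(=O)Nc2ccccc2Cl)C[C@@H]1c1cc(OC)c(OC)c(OC)c1`: 49400 nM
Compound 2 `CCOC(=O)[C@]1(C(=O)NCc2ccc(C)cc2)C[C@H]1c1cc(OC)c(OC)c(OC)c1`: > 100000 nM

Both values come from a functional assay on K562 cells (Homo sapiens) for cytotoxicity, read by MTT assay, with a stated time of 48 h; on this read-out lower numbers stand for stronger inhibition and higher numbers for weaker inhibition. Compound 2 stands at > 100000 nM, which is a limit of this assay and not a number. Among the measured compounds shown here, compound 1, at 49400 nM, supplies the only true number so far.

Compound 3 `CCOC(=O)[C@@]1(C(=O)NCc2ccc(C)cc2)C[C@@H]1c1cc(OC)c(OC)c(OC)c1` has the same atoms and bonds as compound 2 and is its mirror image: the two compounds have the same atoms and bonds and differ only in configuration as drawn: 2 of 2 stereo elements differ (all stereocentres are inverted: mirror images); a stereocentre at a saturated ring carbon is drawn R in compound 2 and S in compound 3; a stereocentre at a saturated ring carbon is drawn S in compound 2 and R in compound 3. For the measured compounds named here, no measured step shows what such an inversion does here, so the expectation is loose. At most a modest step towards stronger inhibition is expected, and possibly none that this assay can resolve, with weak activity the likely outcome. The estimate corresponds to an expected at least 1.1-fold lower number from compound 2 to compound 3 (0.04 log units; that floor lies within the scatter). For compound 3 the estimated value is 90000 nM, with an expected range of 35000 nM to 200000 nM.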

Compound 3, half-maximal inhibitory concentration: > 100000 nM
Compound 3: no number, only a limit (the forecaster's own chance of this, stated with the estimate: 60%); middle value at least 1.1-fold (0.04 log units) away from the limit.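

In this assay compound 3 gives > 100000 nM, which is a limit of the assay and not a number. The step between the two mirror images therefore cannot be read, so this pair does not show whether inverting both stereocentres changes the read-out, because both compounds sit at the same limit: the limit of > 100000 nM in this assay, at which 2 of the 3 values shown sit. The change of 4-methylbenzyl in place of 2-chlorophenyl on an amide-type nitrogen gives an at least 2.0-fold higher number from compound 1 to compound 3 (0.30 log units; that floor lies within the scatter), and since that floor lies within the scatter, it alone does not establish a real loss.

As far as these compounds go, it remains open whether configuration matters in a compound that gives a true number in this assay, such as the mirror image of compound 1. Also open, from the compounds shown here alone, is whether a carboxylic acid in place of the ethyl ester, or an unsubstituted benzyl on the amide-type nitrogen, would give a number rather than a limit.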